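This account rests on a few compounds, and the source may have more. Where it says the series, first, only, none or still open, it means among the compounds named here.

Compound 1 `COC(=O)/C=C/c1cccc(N(Cc2ccc(-c3cccc(Cl)c3)cc2)C(=O)C2CCCCC2)c1` is the reference point of the series. Within the data shown here, in an assay on isolated protein with Bile acid receptor (Homo sapiens) as the target (on this read-out higher numbers stand for an effect only at larger amounts of compound and lower numbers for an effect already at smaller amounts), compound 1 gives 94 nM, the higher of the two numbers measured so far; the nearest is compound 2 `COC(=O)/C=C/c1cccc(N(Cc2ccc(-c3cccc(Cl)c3)cc2)C(=O)C(C)C)c1`, which in this assay gives 77 nM, and the only single-place step in hand is a 1.2-fold lower number from compound 1 to compound 2 (0.09 log units; within the scatter). Compound 3 `COC(=O)/C=C/c1cccc(N(Cc2ccc(/C=C/C(=O)OC(C)(C)C)cc2OC(=O)c2ccccc2)C(=O)C2CCCCC2)c1` differs from compound 1 in more than one place. In this assay compound 3 gives only a limit of the assay, > 1000 nM; this is the limit of > 1000 nM in this assay, at which 1 of the 3 values shown sits.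

Compound 4 `COC(=O)/C=C/c1cccc(N(Cc2ccc(/C=C/C(=O)O)cc2)C(=O)C2CCCCC2)c1` is not yet measured. It differs from compound 1 in one place: 2-carboxyethenyl in place of 3-chlorophenyl on an aromatic carbon. Among the measured compounds shown here, the only measured step, a 1.2-fold lower number from compound 1 to compound 2 (0.09 log units; within the scatter), sits on the carbonyl carbon, not on the aromatic carbon changed here, so no measured step bears directly on this change. The expectation is therefore set with wide bounds, as a step of a 6.4-fold higher number from compound 1 to compound 4 (0.81 log units; beyond the scatter) toward a higher number. In this assay compound 4 is estimated at 600 nM, in the range 150 nM to 3000 nM.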

Compound 4, half-maximal effective concentration: > 1000 nM
Compound 4 ended at the assay's limit; the forecaster's own chance of this, stated with the estimate: 35%; middle value at least 1.6-fold (0.22 log units) from the limit.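

In this assay, this aromatic carbon, para to a large group, responds strongly where the carbonyl carbon did not: 2-carboxyethenyl in place of 3-chlorophenyl gives an at least 10-fold higher number from compound 1 to compound 4 (1.02 log units; beyond the scatter), whereas isopropyl in place of cyclohexyl gave a 1.2-fold lower number from compound 1 to compound 2 (0.09 log units; within the scatter). So the 3-chlorophenyl position is the first place in the series where a single change is shown to move the number beyond the scatter. For compound 4 the value > 1000 nM is a limit of the assay, not a number, so the step fixes only a minimum size: the limit of > 1000 nM in this assay, at which 2 of the 4 values shown sit.

The compounds shown do not separate the departure of 3-chlorophenyl from the arrival of 2-carboxyethenyl. A plain phenyl, a methyl ester or a primary amide on the same aromatic carbon would help to tell the two apart.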